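A few compounds are considered here, and "the series" means these few. Any claim that something is new, unique, unknown or untested is made for them only; others in the source may bear on it.

Measured in an ADME assay on L6 cells (Rattus norvegicus) for cytotoxicity, read by resazurin assay, with a stated time of 5 days; a higher number here means that more compound is tolerated, a lower number that less compound is tolerated:
- compound 1 `CC(=O)Oc1cccc(N2C(=O)/C(=C/N3N=C(c4ccccc4)CC3c3ccccc3O)SC2=S)c1`: 13600 nM
- compound 2 `COc1ccc(C2=NN(/C=C3\SC(=S)N(c4cccc(OC(C)=O)c4)C3=O)C(c3ccccc3O)C2)cc1`: 40000 nM

Compound 1 holds the lower of these two numbers, so it is the less tolerated of the pair. The next compound to be tested, compound 3 `CC(=O)Oc1cccc(N2C(=O)/C(=C/N3N=C(c4ccccc4)CC3c3ccc(N(C)C)cc3)SC2=S)c1`, keeps the core of compound 1 but swaps one group: 4-(dimethylamino)phenyl in place of 2-hydroxyphenyl on a saturated ring carbon. In words, 4-(dimethylamino)phenyl replaces 2-hydroxyphenyl on a saturated ring carbon.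

Among the compounds with values here, only one measured step exists to guide an expectation: a 2.9-fold higher number from compound 1 to compound 2 (0.47 log units; beyond the scatter). That modest step came from methoxy in place of hydrogen on an aromatic carbon, and the 2-hydroxyphenyl group stayed in place. No measurement therefore shows what replacing this group does in this assay, and no direction can be favoured. The expected result is a 1.0-fold lower number from compound 1 to compound 3 (0.02 log units; within the scatter), with no change beyond the scatter. Compound 3 is estimated at 13000 nM, with an expected range of 4500 nM to 40000 nM.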

Compound 3, half-maximal cytotoxic concentration: > 184000 nM
Compound 3 gave a limit, no number; the forecaster's own chance of this, stated with the estimate: 10%; middle value at least 14-fold (1.15 log units) away from the limit.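

Replacing 2-hydroxyphenyl with 4-(dimethylamino)phenyl on the saturated ring carbon gives an at least 13-fold higher number from compound 1 to compound 3 (1.13 log units; beyond the scatter). Within the data shown here, compound 1 and compound 2 share the 2-hydroxyphenyl group, so only this step shows that the group at this position can strongly change how much compound is tolerated in this assay. The result for compound 3 is a limit of the assay, not an exact number: the limit of > 184000 nM in this assay, at which 1 of the 3 values shown sits.

The change removes the hydroxy group and adds the dimethylamino group in one step, so the compounds shown cannot tell which of the two matters, or whether the new group's place on the ring does. A plain phenyl group or a 4-hydroxyphenyl group at this position would help separate these effects, and 4-(diethylamino)phenyl would test whether a larger amine behaves the same way.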